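The compounds below may be only part of what the source reports. "The series", "measured", "known", "first", "only" and "open" are said of these compounds alone.

Of the compounds shown here, three carrying the same core have been tested in a functional assay on Ramos cells (Homo sapiens) for antiproliferative activity, read by CCK-8 assay, with a stated time of 72 h, tested at 40 uM; a higher number here means more inhibition at the concentration tested (going by the name of the read-out), a lower number less inhibition. Compound 1 `CCOC(=O)c1sc(-c2cccc(NC(=O)c3ccc(C(C)(C)C)cc3)c2)nc1Nc1ccc(N2CCN(C)CC2)cc1` gives 21.2%. Compound 2 `CN1CCN(c2ccc(Nc3nc(-c4cccc(NC(=O)c5ccc(C(F)(F)F)cc5)c4)sc3C(N)=O)cc2)CC1` gives 97.8%, and compound 3 `CN1CCN(c2ccc(Nc3nc(-c4cccc(NC(=O)c5ccc(F)cc5)c4)sc3C(N)=O)cc2)CC1` gives 95.9%, the second highest of the three numbers, close to compound 2 and far from compound 1.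

Compound 4 `CN1CCN(c2ccc(Nc3nc(-c4cccc(NC(=O)c5ccc(C(C)(C)C)cc5)c4)sc3C(N)=O)cc2)CC1` differs from compound 3 in one place: tert-butyl in place of fluoro on an aromatic carbon. Going by the values given here, the only measured step at that place is a number 1.9 percentage points lower from compound 2 to compound 3 (within the scatter), which stayed within the scatter. Among the compounds with values here, compound 1 also bears tert-butyl there, but its ester differs from the amide of compound 4, so no step covers it. The expected step of a number 2.9 percentage points lower from compound 3 to compound 4 (within the scatter) is therefore none beyond the scatter. Compound 4 is estimated at 93%, between 72% and 100%.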

Compound 4, a percentage reported as inhibition, at one concentration (the size of the read-out at that concentration, not a potency): 80.1%
For compound 4 the middle estimate is 12.9 percentage points above the measured one, within the range that was stated.
By their numbers in this assay, from the lowest: compound 1; then compound 4; then compounds 3 and 2 (each within the scatter of the next).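

In this assay this aromatic carbon does not accept every group equally: tert-butyl brings a number 15.8 percentage points lower from compound 3 to compound 4 (beyond the scatter) and a number 17.7 percentage points lower from compound 2 to compound 4 (beyond the scatter) while fluoro and trifluoromethyl had remained within the scatter of each other. The amide in place of the ester gives a number 58.9 percentage points higher from compound 1 to compound 4 (beyond the scatter) with tert-butyl held in place, a larger step than either change at the aromatic carbon. No measurement given here explains these steps. As far as these compounds go, whether a methoxy group or a dimethylamino group at this aromatic carbon would match fluoro or tert-butyl remains open, as does the effect of the ester when fluoro or trifluoromethyl occupies this position.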